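Swapping a ring sulfonamide for a thiophene amide

This account rests on a few compounds, and the source may have more. Where it says the series, first, only, none or still open, it means among the compounds named here.

Compound 1 `Cn1cncc1CN1CC(N(CC2CCN(S(C)(=O)=O)CC2)S(=O)(=O)c2ccccn2)Cc2cc(C#N)ccc21` is the starting point here. Going by the values given here, in an ADME assay on Caco-2 cells (Homo sapiens) for permeability, in the apical to basolateral direction (a lower number here means that the compound crosses the layer more slowly, a higher number that the compound crosses the layer faster), compound 1 gives 0.1 10^-6 cm/s, the lowest of the three numbers measured so far. Two close relatives share its core. Compound 2 `Cn1cncc1CN1CC(N(CC2CCN(C(=O)NC(C)(C)C)CC2)S(=O)(=O)c2ccccn2)Cc2cc(C#N)ccc21` carries a (tert-butyl)carbamoyl on the amine nitrogen in the ring and in this assay compound 2 gives 0.6 10^-6 cm/s. Compound 3 `Cn1cncc1CN1CC(N(CC2CCN(C(=O)C3CCCC3)CC2)S(=O)(=O)c2ccccn2)Cc2cc(C#N)ccc21` carries a cyclopentylcarbonyl at the same place and in this assay compound 3 gives 0.5 10^-6 cm/s. The step of a 6.0-fold higher number from compound 1 to compound 2 (0.78 log units; beyond the scatter) and the step of a 5.0-fold higher number from compound 1 to compound 3 (0.70 log units; beyond the scatter) both point the same way, while the step of a 1.2-fold lower number from compound 2 to compound 3 (0.08 log units; within the scatter) shows that the two carbonyl-bearing compounds sit close together.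

Compound 4 `Cn1cncc1CN1CC(N(CC2CCN(C(=O)c3cccs3)CC2)S(=O)(=O)c2ccccn2)Cc2cc(C#N)ccc21` has not yet been measured. It differs from compound 1 as follows: (thiophen-2-yl)carbonyl in place of methylsulfonyl on an amine nitrogen in a ring. The two measured steps that start from compound 1 both exchange the methylsulfonyl for a group joined through a carbonyl, which is also what happens in compound 4, so a rise of similar size in this assay is expected, giving an expected step of a 5.0-fold higher number from compound 1 to compound 4 (0.70 log units; beyond the scatter). For compound 4 the estimated value in this assay is 0.5 10^-6 cm/s, with an expected range from 0.2 10^-6 cm/s to 1.5 10^-6 cm/s.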

Compound 4, apparent permeability: 0.5 10^-6 cm/s
Compound 4: middle estimate and measured number agree at the digits printed, within the range that was stated.
By their numbers in this assay, from the lowest: compound 1; then compounds 3, 4 and 2 (each within the scatter of the next).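

In this assay, going by these compounds alone, the (thiophen-2-yl)carbonyl brings a five-membered aromatic ring to the amine nitrogen in the ring, which no earlier compound carried there, and the result is a 5.0-fold higher number from compound 1 to compound 4 (0.70 log units; beyond the scatter), so the gain over methylsulfonyl now holds for three different groups joined through a carbonyl. What sits on the carbonyl carbon has so far made no readable difference: thiophen-2-yl in place of cyclopentyl gives no change at the digits printed from compound 3 to compound 4 (within the scatter) and thiophen-2-yl in place of (tert-butyl)amino gives a 1.2-fold lower number from compound 2 to compound 4 (0.08 log units; within the scatter), which puts an aromatic ring, a saturated ring and a branched amino group within the scatter of one another at this position. Nothing measured here explains why these three compounds stand apart from compound 1.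

The compounds shown leave open whether the carbonyl link itself matters, since a group joined directly to the ring nitrogen, such as a plain benzyl, does not appear among them. They also leave open how a carbonyl group bearing an amine or a carboxylic acid on a longer chain would read, and whether a sulfonyl carrying a phenyl instead of methyl would stay close to compound 1.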